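The source may hold more compounds than are shown below. What is called first, only, known or untested is meant among the compounds shown, and "the series" means these compounds.

Three compounds have numbers in a functional assay on HeLa cells (Homo sapiens) for antiproliferative activity, read by CCK-8 assay, with a stated time of 72 h; a higher number here means a weaker inhibitor, a lower number a stronger inhibitor. Compound 1 `Nc1ccccc1NC(=O)c1ccc(Cn2cnc3c(Nc4ccc(-c5ccccn5)cc4)nc(Cl)nc32)cc1` reads > 20000 nM, which is a limit of the assay and not a number. Compound 2 `Nc1ccccc1NC(=O)c1ccc(COCNc2nc(Nc3ccccc3)c3ncn(C4CCCC4)c3n2)cc1` gives 8700 nM. Compound 3 `CCCCn1cnc2c(Nc3ccccc3)nc(NCOCc3ccc(C(=O)Nc4ccccc4N)cc3)nc21` gives 3290 nM, the lowest of the two actual numbers and so the best starting point on hand. Its edge over compound 2 comes from one swap, butyl in place of cyclopentyl on an aromatic nitrogen, which makes up the modest step of a 2.6-fold lower number from compound 2 to compound 3 (0.42 log units; beyond the scatter).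

Compound 4 `CCCCn1cnc2c(Nc3cccc(Cl)c3)nc(NCOCc3ccc(C(=O)Nc4ccccc4N)cc3)nc21` keeps all of compound 3 except for one place, where phenyl becomes 3-chlorophenyl (chloro in place of hydrogen on an aromatic carbon). Among the measured compounds shown here, no measured step touches this ring. For the measured compounds named here, the one measured single change, the step from butyl to cyclopentyl's replacement in compound 3 at 3290 nM, lies elsewhere in the molecule, so it offers a rough sense of scale but no direction. A change of about that modest size or smaller is therefore expected in this assay, most likely staying within the scatter. The expected change is a 1.2-fold lower number from compound 3 to compound 4 (0.07 log units; within the scatter). The estimate for compound 4 is 2800 nM, with an expected range from 1000 nM to 8000 nM.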

Compound 4, half-maximal inhibitory concentration: 6780 nM
Estimate against measurement, compound 4: 2.4-fold (0.38 log units) below; measured number inside the range.
By their numbers in this assay, from the lowest: compound 3; then compounds 4 and 2 (each within the scatter of the next). At a limit, above all of these: compound 1.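

In this assay, chloro in place of hydrogen on an aromatic carbon, meta to a large group, gives a 2.1-fold higher number from compound 3 to compound 4 (0.31 log units; beyond the scatter), so the higher number means a weaker inhibitor. Among the compounds shown here, this is the first measured sign that the phenyl ring of the anilino group affects the read-out at all, since the only earlier single change, at the aromatic nitrogen, was a 2.6-fold lower number from compound 2 to compound 3 (0.42 log units; beyond the scatter); both steps are modest, but they run in opposite directions, and at this position the one added chlorine atom moved the number the wrong way. The information shown gives no reason for this rise, and nothing in it bears on the result.

Still open, going by these compounds, is what other groups would do on this ring: a fluoro, a methoxy or an amine in the same place could raise the number or lower it, and chloro on another carbon of the ring might not act as it does here. Also open, on these data alone, is whether chloro at this position would raise the number in the same way with cyclopentyl on the aromatic nitrogen, as in compound 2.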